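A few compounds are considered here, and "the series" means these few. Any claim that something is new, unique, unknown or untested is made for them only; others in the source may bear on it.

Working notes on the series, which shares one core and varies the group on an amide-type nitrogen. In a functional assay on KB 3-1 cells (Homo sapiens) for cytotoxicity, read by MTT assay, with a stated time of 72 h (a higher number here means a weaker inhibitor, a lower number a stronger inhibitor), compound 2 `O=C1Nc2ccccc2/C1=N/NC(=S)Nc1cccnc1` gives > 50000 nM, which is a limit of the assay and not a number. Compound 1 `O=C1Nc2ccccc2/C1=N/NC(=S)Nc1ccccc1` gives 3530 nM. Compound 3 `O=C1Nc2ccccc2/C1=N/NC(=S)NC1CCCCC1` gives 9140 nM.

Compound 4 `O=C1Nc2ccccc2/C1=N/NC(=S)Nc1ccc(Cl)cc1` has 4-chlorophenyl in place of pyridin-3-yl on an amide-type nitrogen. Going by the values given here, two measured steps bear most directly on this change: an at least 14-fold higher number from compound 1 to compound 2 (1.15 log units; beyond the scatter) for pyridin-3-yl in place of phenyl, and an at least 5.4-fold lower number from compound 2 to compound 3 (0.73 log units; beyond the scatter) for cyclohexyl in place of pyridin-3-yl. Both show a lower number wherever pyridin-3-yl is absent, and the first is large. Among the compounds with values here, no measured compound carries a substituted phenyl, so the estimate is anchored on compound 1 at 3530 nM. A large step to a lower number is therefore expected in this assay. The estimated step is an at least 17-fold lower number from compound 2 to compound 4 (1.25 log units; beyond the scatter). For compound 4 the estimated value is 2800 nM, with an expected range of 900 nM to 9000 nM.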

Compound 4, half-maximal inhibitory concentration: 13400 nM
Compound 4: middle estimate off by 4.8-fold (0.68 log units), on the low side; the measured number lies above the stated range.
By their numbers in this assay, from the lowest: compound 1; then compounds 3 and 4 (each within the scatter of the next). At a limit, above all of these: compound 2.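

In this assay, chloro in place of hydrogen on an aromatic carbon gives a 3.8-fold higher number from compound 1 to compound 4 (0.58 log units; beyond the scatter), so in this first substituted phenyl of the series, a six-membered aromatic ring of carbon only does not by itself keep the number low. Against pyridin-3-yl, 4-chlorophenyl gives an at least 3.7-fold lower number from compound 2 to compound 4 (0.57 log units; beyond the scatter), a step that rests on a limit of the assay and not on a number. 4-Chlorophenyl and cyclohexyl on the amide-type nitrogen are not told apart, with a 1.5-fold higher number from compound 3 to compound 4 (0.17 log units; within the scatter).

The compounds shown leave open whether fluoro or methoxy on the phenyl ring would give the same rise, or whether it belongs to chloro alone. They also do not tell how an amine on that ring, or a longer chain in place of cyclohexyl, would read in this assay.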